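Two limit values and a pyridazinyl replacement

A few compounds are considered here, and "the series" means these few. Any claim that something is new, unique, unknown or untested is made for them only; others in the source may bear on it.

compound 1 `O=C(NO)c1cc(F)c(Cn2nnc(-c3ccco3)n2)c(F)c1`: > 1000 nM
compound 2 `Cn1c(Sc2c(F)cc(C(=O)NO)cc2F)nnc1-c1cccs1`: > 1000 nM

In an ADME assay on 697 cells (Homo sapiens) for cytotoxicity, with a stated time of 48 h (a higher number here means a weaker inhibitor, a lower number a stronger inhibitor), compound 2 gives > 1000 nM, a limit of the assay and not a number. Compound 1 offers no number either: the limit of > 1000 nM in this assay, at which 2 of the 2 values shown sit. Compound 3 `Cn1c(Sc2c(F)cc(C(=O)NO)cc2F)nnc1-c1cccnn1` carries pyridazin-3-yl in place of thiophen-2-yl on an aromatic carbon. Within the data shown here, no measured step is available as a guide, so no change beyond the scatter is expected in this assay. The expected step is a step that the limit leaves unreadable from compound 2 to compound 3, an estimate within the scatter. Compound 3 is estimated at 1500 nM, with an expected range of 600 nM to 4000 nM.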

Compound 3, half-maximal inhibitory concentration: > 1000 nM
Compound 3: a limit, no number; the forecaster's own chance of this, stated with the estimate: 75%; the middle value does not contradict the limit.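

Compound 2 and compound 3 yield no readable step in this assay, as both values are limits: the limit of > 1000 nM in this assay, at which 3 of the 3 values shown sit.

Still open, from the compounds shown here alone, is whether pyridazin-3-yl in place of thiophen-2-yl changes anything, and which compound would give a number in this assay rather than a limit.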